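The source may report more compounds than this note shows. Statements on the series, on what has been measured and on what is new or still open speak of the compounds shown alone.

Three compounds on the shared core have numbers in a functional assay on HT cells (Homo sapiens) for antiproliferative activity, read by fluorescence, with a stated time of 72 h; on this read-out higher numbers stand for weaker inhibition of growth and lower numbers for stronger inhibition of growth: compound 1 `CC(C)c1n[nH]c2c(NCc3ccc(-c4ccccn4)cc3)nc(SCC(O)CO)nc12` gives 21 nM, compound 2 `CC(C)c1n[nH]c2c(NCc3ccc(-c4ccccn4)cc3)nc(SC(C)C(C)O)nc12` gives 190 nM and compound 3 `CC(C)c1n[nH]c2c(NCc3ccc(-c4ccccn4)cc3)nc(SCC(C)(C)N)nc12` gives 85 nM. Compound 3 holds the second highest of the three numbers. The next compound is compound 4 `CC(C)c1n[nH]c2c(NCc3ccc(-c4ccccn4)cc3)nc(SC3CCCC3O)nc12`, with 2-hydroxycyclopentyl in place of 2-amino-2-methylpropyl on a sulfur. Among the measured compounds shown here, no measured step covers this exchange directly. Among the measured groups, 2-hydroxy-1-methylpropyl in compound 2 comes nearest to 2-hydroxycyclopentyl, although it has no ring. The most relevant step is therefore a 2.2-fold lower number from compound 2 to compound 3 (0.35 log units; beyond the scatter), and reversing it points to a higher number. The other changes on the sulfur, a 9.0-fold higher number from compound 1 to compound 2 (0.96 log units; beyond the scatter) and a 4.0-fold higher number from compound 1 to compound 3 (0.61 log units; beyond the scatter), are also modest, so a large move is not expected. The estimated step is a 1.6-fold higher number from compound 3 to compound 4 (0.22 log units; within the scatter), a small rise that may stay close to the scatter. For compound 4 the expected value in this assay is 140 nM, with an estimated range of 50 nM to 380 nM.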

Compound 4, concentration for 50% growth inhibition: 567 nM
Compound 4: the middle estimate sits 4.1-fold (0.61 log units) below what was measured, outside the stated range (above it).
By their numbers in this assay, from the lowest: compound 1; then compound 3; then compound 2; then compound 4.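

In this assay, 2-hydroxycyclopentyl on the sulfur gives the highest number of the four compounds, with a 6.7-fold higher number from compound 3 to compound 4 (0.82 log units; beyond the scatter) and a 3.0-fold higher number from compound 2 to compound 4 (0.47 log units; beyond the scatter) and, against the 2,3-dihydroxypropyl group, a 27-fold higher number from compound 1 to compound 4 (1.43 log units; beyond the scatter). Groups carrying a hydroxyl now span the whole range, from compound 1 to compound 4, with the amine-bearing compound 3 inside it, so a hydroxyl on this chain does not alone set the number. No supporting data on hand explain the weaker growth inhibition of compound 4.

On these data alone, whether the five-membered ring itself or the placement of its hydroxyl drives this rise remains open. A 2-aminocyclopentyl group or a 2-hydroxycyclohexyl group on the sulfur would help separate the ring from the group it carries, and a 3-hydroxypropyl chain would test the open-chain side.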